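The source may hold more compounds than are shown below. What is called first, only, known or untested is meant among the compounds shown, and "the series" means these compounds.

Measured so far:
compound 1 `Cc1ccc(NS(=O)(=O)c2ccc(N3CCNC3=O)cc2)cc1` — a functional assay on MCF7 cells (Homo sapiens) for antiproliferative activity, read by sulforhodamine B assay, with a stated time of 48 h; a lower number here means a stronger inhibitor, a higher number a weaker inhibitor: 610 nM
compound 2 `CCCCCCCc1ccc(NS(=O)(=O)c2ccc(N3CCNC3=O)cc2)cc1` — this assay: > 1000 nM

For the measured compounds named here, compound 1 is the only compound of the pair with a number in this assay. For compound 2 the value is a limit of the assay, not a number, so the step of an at least 1.6-fold higher number from compound 1 to compound 2 (0.21 log units; that floor lies within the scatter) is known only as a floor, and that floor lies within the scatter (the limit of > 1000 nM in this assay, at which 1 of the 2 values shown sits).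

Compound 3 `Cc1ccccc1NS(=O)(=O)c1ccc(N2CCNC2=O)cc1` is not yet measured. It differs from compound 1 by 2-methylphenyl in place of 4-methylphenyl on a sulfonamide nitrogen. Going by the values given here, the one measured step, hexyl in place of hydrogen on a saturated chain carbon bound to an aromatic carbon, changes a different part of the same group and gives no direction that can be carried over, since its size is only a floor within the scatter.

No step beyond the scatter is therefore expected for compound 3; the move a 1.1-fold higher number from compound 1 to compound 3 (0.06 log units; within the scatter) is the estimate. Compound 3 is expected to give about 700 nM in this assay, between 300 nM and 1600 nM.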

Compound 3, half-maximal inhibitory concentration: 280 nM
Compound 3: middle estimate off by 2.5-fold (0.40 log units), on the high side; measured number below the stated range.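

Moving from 4-methylphenyl to 2-methylphenyl on a sulfonamide nitrogen gives, in this assay, a 2.2-fold lower number from compound 1 to compound 3 (0.34 log units; beyond the scatter), the first step in the series that can be read beyond the scatter. The two groups hold the same atoms joined differently, so this assay responds to the arrangement of this group alone, with no change in what is counted for it. Nothing shown gives a reason for this shift.

On these data alone, compound 2 gives only a limit, so the size of its step cannot be read and the effect of a longer chain stays undefined: the limit of > 1000 nM in this assay, at which 1 of the 3 values shown sits. It remains open whether an ethyl group, a chlorine or a methoxy group in place of the methyl on 2-methylphenyl would keep the lower number, and whether changes to the shared core would act in the same direction.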